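Sulfamoyl in Place of Methylpiperazine on Two Related Cores

The source may report more compounds than this note shows. Statements on the series, on what has been measured and on what is new or still open speak of the compounds shown alone.

Compound 1, `CN1CCN(c2ccc(Nc3ncc(/N=C/c4ccccc4)c(NC4CCCC4)n3)cc2)CC1`, gives 28600 nM in a functional assay on HT-29 cells (Homo sapiens) for antiproliferative activity, read by MTT assay; on this read-out higher numbers stand for weaker inhibition and lower numbers for stronger inhibition.
Compound 2, `NS(=O)(=O)c1ccc(Nc2ncc(/N=C/c3ccccc3)c(NC3CCCC3)n2)cc1`, gives 27000 nM.
Compound 3, `CCOC(=O)/C=N/c1cnc(Nc2ccc(N3CCN(C)CC3)cc2)nc1NC(C)C`, gives 7590 nM.

Compound 2 arises from compound 1 by one change, (sulfamoyl in place of 4-methylpiperazin-1-yl on an aromatic carbon). That step, a 1.1-fold lower number from compound 1 to compound 2 (0.03 log units; within the scatter), left the number essentially where it was. Compound 4, `CCOC(=O)/C=N/c1cnc(Nc2ccc(S(N)(=O)=O)cc2)nc1NC(C)C`, is not yet measured in this assay; it arises from compound 3 by the same change at the same place, (sulfamoyl in place of 4-methylpiperazin-1-yl on an aromatic carbon). How the core of compound 3 differs from the core of compound 1 is not broken down here. Compound 3 has the lowest of the three measured numbers, beyond the scatter from both others. A step of similar size is expected this time, a 1.1-fold lower number from compound 3 to compound 4 (0.04 log units; within the scatter), because the earlier step of a 1.1-fold lower number from compound 1 to compound 2 (0.03 log units; within the scatter) lay within the scatter. Compound 4 is therefore estimated at 7000 nM, likely between 2500 nM and 20000 nM.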

Compound 4, half-maximal inhibitory concentration: > 100000 nM
Compound 4 ended at the assay's limit; the forecaster's own chance of this, stated with the estimate: 10%; at least 14-fold (1.15 log units) between middle value and limit.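

The swap of 4-methylpiperazin-1-yl for sulfamoyl gave an at least 13-fold higher number from compound 3 to compound 4 (1.11 log units; beyond the scatter) in this assay, so the near-flat result on the core of compound 1 did not carry over to the core of compound 3: the same change on two cores in this assay, a 1.1-fold lower number (0.03 log units; within the scatter) from compound 1 to compound 2 and an at least 13-fold higher number (1.11 log units; beyond the scatter) from compound 3 to compound 4, at least 13-fold (1.14 log units) apart, beyond the scatter of two such steps. Compound 4 gives > 100000 nM, which is a limit of the assay and not a number, so the step is a bound and not an exact size: the limit of > 100000 nM in this assay, at which 1 of the 4 values shown sits. The result shows that the outcome of this change differs between these two cores, but it does not show which difference between the cores matters, or why.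

Among the compounds shown here, with only two pairs, it remains open whether other cores would follow compound 1 or compound 3. Also open, as far as these compounds go, is how a carboxylic acid or an amide in the same place would behave on the core of compound 3.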